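This account rests on a few compounds, and the source may have more. Where it says the series, first, only, none or still open, it means among the compounds named here.

Measured in an assay on isolated protein for inhibition of thiosulfate sulfurtransferase (Homo sapiens), with a stated time of 60 min, in the absence of a further agent; on this read-out lower numbers stand for stronger inhibition and higher numbers for weaker inhibition:
Compound 1 `O=C(Nc1ccccc1)c1cc(Br)ccc1O`: > 100000 nM, a limit of the assay.
Compound 2 `O=C(Nc1cccc(Cl)c1)c1cccc(Br)c1`: > 100000 nM, a limit of the assay.
Compound 3 `COc1c(Br)cccc1C(=O)Nc1cccc(Cl)c1`: > 100000 nM, a limit of the assay.

Compound 2 stands only at a limit in this assay; the two other values are limits as well, all sitting at the limit of > 100000 nM in this assay, at which 3 of the 3 values shown sit. The step that the two limits leave unreadable from compound 2 to compound 3 is therefore unreadable. The change to compound 4 `O=C(Nc1cccc(Cl)c1)c1cc(Br)ccc1O` is hydroxy in place of hydrogen on an aromatic carbon. Among the compounds with values here, no measured step covers this change; compound 1 also carries a hydroxy and gives only a limit in this assay. With every value at the limit, no step beyond the scatter is expected in this assay, and the step that the limit leaves unreadable from compound 2 to compound 4 is an estimate only. Compound 4 is expected at 200000 nM, in the range 50000 nM to 1000000 nM, most likely reported again as a limit.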

Compound 4, half-maximal inhibitory concentration: > 100000 nM
Compound 4 ended at the assay's limit; the forecaster's own chance of this, stated with the estimate: 85%; the middle value is on the limit's open side.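

Neither the step from compound 2 to compound 4 nor the step from compound 1 to compound 4 can be read, because each pair gives only limits: the limit of > 100000 nM in this assay, at which 4 of the 4 values shown sit. The compounds shown leave open whether any change to the shared core gives measurable inhibition.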